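Swapping a Hydroxypropyl Chain for a Propenyl Group

A few compounds are considered here, and "the series" means these few. Any claim that something is new, unique, unknown or untested is made for them only; others in the source may bear on it.

Measured so far:
- compound 1 `COc1ccc(-c2cc3cc(CCCO)ccc3o2)c(O)c1`: 27200 nM
- compound 2 `C/C=C/c1ccc2oc(-c3ccc(O)cc3)cc2c1`: > 50000 nM

Two compounds share a fused two-ring core carrying an aryl group, and both were tested in an assay on isolated protein for inhibition of Polyunsaturated fatty acid 5-lipoxygenase (Homo sapiens); a higher number here means a weaker inhibitor, a lower number a stronger inhibitor. Compound 1 gives 27200 nM, the only numeric result in this set. Compound 2 returns a limit of the assay rather than a number, > 50000 nM. Going by the values given here, compound 1 therefore stands as the single measured value, with the other result sitting at the limit described in the limit of > 50000 nM in this assay, at which 1 of the 2 values shown sits. Among the compounds with values here, no step between two measured compounds can be computed here, since the two differ in more than one place.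

Compound 3 `C/C=C/c1ccc2oc(-c3ccc(OC)cc3O)cc2c1` is not yet measured. It differs from compound 1 by one change, (prop-1-en-1-yl in place of 3-hydroxypropyl on an aromatic carbon). Because compound 2 already carries this propenyl group and reaches only the limit > 50000 nM, a weakening is expected rather than a gain. For compound 3 the expected value in this assay is 40000 nM, within a range from 12000 nM to 120000 nM, with the step from compound 1 estimated as a 1.5-fold higher number from compound 1 to compound 3 (0.17 log units; within the scatter).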

Compound 3, half-maximal inhibitory concentration: > 50000 nM
Compound 3: no number, only a limit; the forecaster's own chance of this, stated with the estimate: 45%; middle value at least 1.2-fold (0.09 log units) away from the limit.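

Going by these compounds alone, this is the first step that can be read at this position, and in this assay the swap of 3-hydroxypropyl for prop-1-en-1-yl gives an at least 1.8-fold higher number from compound 1 to compound 3 (0.26 log units; that floor lies within the scatter). Since the floor of that step lies within the scatter, it does not establish a real loss, but the swap produces no measurable gain in inhibition, and the chain's hydroxyl group is not replaced by any hydrogen-bond donor or acceptor in the entering group. Compound 3 returns a limit of the assay rather than a number, so only a floor can be given for the step, and the true size of the change stays unknown: the limit of > 50000 nM in this assay, at which 2 of the 3 values shown sit.

The compounds shown leave open whether the outcome at this position follows from losing the hydroxyl group, from gaining the double bond, or from both, since the swap makes both changes at once. A plain propyl chain would separate those two changes, while a 3-aminopropyl chain or a carboxylic acid at the end of the chain would test other end groups on the same core.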